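Replacing thiophen-2-yl with pyridin-2-yl in a cytotoxicity set

This account rests on a few compounds, and the source may have more. Where it says the series, first, only, none or still open, it means among the compounds named here.

Values measured in a functional assay on HeLa cells (Homo sapiens) for cytotoxicity, read by ELISA, with a stated time of 2 days (on this read-out higher numbers stand for weaker inhibition and lower numbers for stronger inhibition), follow
Compound 1 `Oc1cccc(-c2cc(-c3ccccc3)cc(-c3cccs3)n2)c1` gives 17000 nM
Compound 2 `Oc1ccccc1-c1cc(-c2ccccc2)nc(-c2ccco2)c1` gives 9700 nM
Compound 3 `Oc1cccc(-c2cc(-c3ccccc3)nc(-c3cccs3)c2)c1` gives 15300 nM

All three numbers lie within the usual scatter of repeated measurements of one another. Within the data shown here, compound 3 (15300 nM) therefore cannot be separated from compound 1 or compound 2, and no compound here stands out.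

The next compound is compound 4 `Oc1cccc(-c2cc(-c3ccccc3)nc(-c3ccccn3)c2)c1`. It has pyridin-2-yl in place of thiophen-2-yl on an aromatic carbon and is otherwise the same as compound 3.

Among the measured compounds shown here, no two measured compounds differ in just one place, so the data hold no direct measure of such a swap. For the measured compounds named here, the only guide is how closely the measured values sit, with compound 2 (9700 nM) and compound 1 (17000 nM) still within the scatter of each other. In this assay no step beyond the scatter is expected in either direction (estimated: a 1.2-fold lower number from compound 3 to compound 4 (0.07 log units; within the scatter)). For compound 4 the estimated value is 13000 nM, with an expected range from 5500 nM to 30000 nM.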

Compound 4, half-maximal inhibitory concentration: 29800 nM
The estimate for compound 4 lay 2.3-fold (0.36 log units) below the measured number; low and high end bracket the measured number.
By their numbers in this assay, from the lowest: compounds 2, 3, 1 and 4 (each within the scatter of the next, the first and the last beyond it).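

Among these compounds, this pair is the first in the set that differs in only one place, so it gives the first direct reading of a change at this position. In this assay, pyridin-2-yl in place of thiophen-2-yl on the aromatic carbon next to the ring nitrogen gives a 1.9-fold higher number from compound 3 to compound 4 (0.29 log units; within the scatter), so this swap of a five-membered aromatic ring for a six-membered one cannot be told apart from repeat-to-repeat variation. No supporting measurement bears on this result.

As far as these compounds go, it remains open whether a different kind of group at this position, such as an amine, a carboxylic acid or a longer chain, would give a step beyond the scatter. From the compounds shown here alone, it is also open whether the same swap would read alike in compound 1, which also carries thiophen-2-yl.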